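Benzyl oxime ether variation on a shared indole-fused core

A few compounds are considered here, and "the series" means these few. Any claim that something is new, unique, unknown or untested is made for them only; others in the source may bear on it.

Measured compounds:
compound 1 `O=[N+]([O-])c1ccc2c(c1)/C(=N\O)C(c1c[nH]c3ccc([N+](=O)[O-])cc13)=N2` 10400 nM
compound 2 `Cc1ccc(CO/N=C2/C(c3c[nH]c4ccccc34)=Nc3ccccc32)cc1` 22400 nM
compound 3 `Cc1ccc(CO/N=C2/C(c3c[nH]c4ccc(F)cc34)=Nc3ccc(F)cc32)cc1` 13600 nM

In a functional assay on A549 cells (Homo sapiens) for cytotoxicity, read by MTT assay, with a stated time of 2 days (a higher number here means a weaker inhibitor, a lower number a stronger inhibitor), compound 1 gives 10400 nM. In this assay compound 2 gives 22400 nM and compound 3 gives 13600 nM. Compound 2 stands at the highest of the three numbers; the nearest to it is compound 3, whose number sits within the scatter of repeated measurement, while compound 1 sits furthest away, beyond the scatter on the lower side. Compound 4 `Fc1ccc(CO/N=C2/C(c3c[nH]c4ccccc34)=Nc3ccccc32)c(Cl)c1` has not yet been measured in this assay. It differs from compound 2 in one place: 2-chloro-4-fluorophenyl in place of 4-methylphenyl on a saturated chain carbon bound to an oxygen on an unsaturated carbon. For the measured compounds named here, no step between measured compounds matches this change, so nothing among the three numbers tells how swapping the 4-methylbenzyl for the 2-chloro-4-fluorobenzyl will read. The shared core is untouched, and the whole measured range spans only a modest spread, so the expected step from compound 2 to compound 4 is a 1.4-fold lower number from compound 2 to compound 4 (0.15 log units; within the scatter), which may well fall within the scatter in either direction. For compound 4 the estimate in this assay is 16000 nM, with a range from 5000 nM to 45000 nM.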

Compound 4, half-maximal inhibitory concentration: 21400 nM
Estimate against measurement, compound 4: 1.3-fold (0.13 log units) below; low and high end bracket the measured number.
By their numbers in this assay, from the lowest: compounds 1, 3, 4 and 2 (each within the scatter of the next, the first and the last beyond it).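

In this assay the step at this position, on a saturated chain carbon bound to an oxygen on an unsaturated carbon, reads a 1.0-fold lower number from compound 2 to compound 4 (0.02 log units; within the scatter) and so sets 2-chloro-4-fluorophenyl level with 4-methylphenyl, although the entering group carries a fluorine and a chlorine where the leaving group has carbon only. For the compounds shown here, with the shared core held fixed, this pair gives the first direct reading of a change at this position, which no step among the earlier compounds could give, and here the exchange of 4-methylbenzyl for 2-chloro-4-fluorobenzyl leaves the two compounds indistinguishable. Nothing shown here offers an explanation for this result.

Going by these compounds, whether this holds for other groups at the same position stays open, since a single step between two substituted benzyl groups says nothing about an unsubstituted benzyl, a longer chain in place of the benzyl, or an amine or a carboxylic acid on the ring. On these data alone, it is also open whether the same exchange would read alike on the core of compound 3 or on the core of compound 1.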